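This account rests on a few compounds, and the source may have more. Where it says the series, first, only, none or still open, it means among the compounds named here.

In a functional assay on OVCAR cells (Homo sapiens) for cytotoxicity, read by sulforhodamine B assay, with a stated time of 48 h (a lower number here means a stronger inhibitor, a higher number a weaker inhibitor), compound 1 `O=CCN1N=C(c2ccc3ccccc3c2)CC1c1cccc([N+](=O)[O-])c1` gives 3390 nM. Compound 2 `O=CCN1N=C(c2ccc3ccccc3c2)CC1c1ccccc1[N+](=O)[O-]` gives 3480 nM in the same setting, and the step of a 1.0-fold higher number from compound 1 to compound 2 (0.01 log units; within the scatter) stays within the scatter. Among the compounds with values here, compound 3 `O=CCN1N=C(c2ccc3ccccc3c2)CC1c1cccc(Br)c1` gives 10800 nM, the highest of the three numbers measured so far; its nearest neighbour is compound 2, and both a 3.2-fold higher number from compound 1 to compound 3 (0.50 log units; beyond the scatter) and a 3.1-fold higher number from compound 2 to compound 3 (0.49 log units; beyond the scatter) lie beyond the scatter, each a modest step toward weaker inhibition.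

Compound 4 `O=CCN1N=C(c2ccc3ccccc3c2)CC1/C=C/c1ccccc1` has not yet been measured in this assay. It differs from compound 3 in one place: 2-phenylethenyl in place of 3-bromophenyl on a saturated ring carbon. Within the data shown here, no measured step exchanges an aryl group on that saturated ring carbon for an alkenyl one, so the measured steps speak to this change only indirectly. They show that what sits on that carbon can move the number by a modest amount, as seen from compound 1 and compound 2 to compound 3, while shifting the nitro group around the ring did nothing beyond the scatter. Among the measured compounds shown here, with no direct precedent, the expectation for compound 4 is no step beyond the scatter, that is a 1.4-fold lower number from compound 3 to compound 4 (0.13 log units; within the scatter). Compound 4 is therefore estimated at 8000 nM, with a range from 2500 nM to 25000 nM.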

Compound 4, half-maximal inhibitory concentration: 18100 nM
Estimate against measurement, compound 4: 2.3-fold (0.35 log units) below; the range from low to high includes it.
By their numbers in this assay, from the lowest: compounds 1 and 2 (each within the scatter of the next); then compounds 3 and 4 (each within the scatter of the next).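

In this assay, the 2-phenylethenyl group on the saturated ring carbon reads level with the 3-bromophenyl group (a 1.7-fold higher number from compound 3 to compound 4 (0.22 log units; within the scatter)), so a group that holds its phenyl ring one double bond away from that carbon fits with the directly attached bromophenyl result. Set against the two nitro compounds, the same group gives modest steps beyond the scatter, both toward weaker inhibition (a 5.2-fold higher number from compound 2 to compound 4 (0.72 log units; beyond the scatter)) and (a 5.3-fold higher number from compound 1 to compound 4 (0.73 log units; beyond the scatter)), so among these four compounds the two with a nitrophenyl group form the lower pair, and neither compound 3 nor compound 4 goes against that split. Nothing measured here explains why the numbers divide this way.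

The compounds shown leave open whether a nitro group on the phenyl ring of the 2-phenylethenyl group would bring the number back to the level of compound 1 and compound 2, and whether a 2-phenylethyl group, without the double bond, would stay level with compound 4. They also leave open how an amine or a carboxylic acid on that phenyl ring would read in this setting.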